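Amide variation on the shared core: working notes

The source may hold more compounds than are shown below. What is called first, only, known or untested is meant among the compounds shown, and "the series" means these compounds.

Measured so far in a functional assay on the whole organism (strain Wistar) for inhibition, with Rattus norvegicus as the target, read by paw edema, with stated times of 60 min and 24 h, at a dose of 100 mg/kg by the oral route; on this read-out higher numbers stand for more inhibition at the one dose given (going by the name of the read-out) and lower numbers for less inhibition:
compound 1, `CCCNC(=O)CC1CCc2cc(OC)c(OC)cc21`, gives 26.7%
compound 2, `CCCCCCNC(=O)CC1CCc2cc(OC)c(OC)cc21`, gives 45.5%
compound 3, `COc1cc2c(cc1OC)C(CC(=O)N1CCCC1)CC2`, gives 33.3%

Compound 1 has the lowest of the three numbers. Lengthening the chain at the amide end gives a number 18.8 percentage points higher from compound 1 to compound 2 (beyond the scatter), and closing the amide into a ring from the propyl compound gives a number 6.6 percentage points higher from compound 1 to compound 3 (within the scatter), which stays within the scatter. Going from the hexyl compound to the ring amide gives a number 12.2 percentage points lower from compound 2 to compound 3 (beyond the scatter).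

Compound 4, `COc1cc2c(cc1OC)C(CC(=O)N1CCNCC1)CC2`, has not been measured. Relative to compound 1 the change is piperazin-1-yl in place of propylamino on a carbonyl carbon. The step that bears most directly on this is the one in which a ring replaces the propylamino group, a number 6.6 percentage points higher from compound 1 to compound 3 (within the scatter), which did not move the number beyond the scatter. Going by the values given here, the ring in compound 4 differs from the one in compound 3 in size and in what is counted, so that step is only a rough guide, and no measured step covers a second nitrogen in the ring. The step is therefore expected to be small, a number 4.3 percentage points higher from compound 1 to compound 4 (within the scatter), within the scatter. The estimate for compound 4 is 31%, with a range from 17% to 46%.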

Compound 4, a percentage reported as inhibition, in the whole organism at one dose (the size of the read-out at that dose, not a potency): 65%
Estimate against measurement, compound 4: 34 percentage points below, and the stated range ends below it.
By their numbers in this assay, from the lowest: compounds 1 and 3 (each within the scatter of the next); then compound 2; then compound 4.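

On a carbonyl carbon whose other neighbour is a saturated chain carbon, the piperazin-1-yl group in this assay gives a number 38.3 percentage points higher from compound 1 to compound 4 (beyond the scatter) and also a number 31.7 percentage points higher from compound 3 to compound 4 (beyond the scatter) so the kind of ring matters here, whereas the earlier change from propylamino to pyrrolidin-1-yl stayed within the scatter. Going by these compounds alone, compound 4 also exceeds the hexyl amide, with a number 19.5 percentage points higher from compound 2 to compound 4 (beyond the scatter) and now has the highest number of the four, so a longer chain on the amide nitrogen is not the only change linked to a higher number. Nothing available on these compounds accounts for the rise seen with piperazin-1-yl.

The compounds shown leave open how a piperidin-1-yl or morpholin-4-yl group on the same carbonyl carbon would compare, and so whether the higher number goes with the second ring nitrogen or with the six-membered ring itself. From the compounds shown here alone, a methyl or acetyl group on the free ring nitrogen of piperazin-1-yl also remains open, and each number stands for a single dose, which gives no reading of potency.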